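Methoxybenzyl in place of dichlorobenzyl on a shared diamine core

This account rests on a few compounds, and the source may have more. Where it says the series, first, only, none or still open, it means among the compounds named here.

compound 1 `CCOC(=O)[C@H](CCC(=O)O)NC(=O)c1ccc(CNc2nc3cc(N)cc(N)c3nc2-c2ccccc2)cc1`: < 100000 nM
compound 2 `Nc1cc(N)c2nc(-c3ccccc3)c(NCc3ccc(Cl)c(Cl)c3)nc2c1`: 5890 nM

In a functional assay on IGROV-1 cells (Homo sapiens) for inhibition, read by sulforhodamine B assay, with a stated time of 48 h (on this read-out higher numbers stand for weaker inhibition of growth and lower numbers for stronger inhibition of growth), compound 1 gives < 100000 nM, which is a limit of the assay rather than a number (the limit of < 100000 nM in this assay, at which 1 of the 2 values shown sits). In this assay compound 2 gives 5890 nM, the only number shown, so it stands alone among the measured values. Compound 3 `COc1ccc(CNc2nc3cc(N)cc(N)c3nc2-c2ccccc2)cc1` differs from compound 2 by 4-methoxyphenyl in place of 3,4-dichlorophenyl on a saturated chain carbon bound to a nitrogen on an aromatic ring. Going by the values given here, no step between measured compounds is known, so the size of this step is open; a modest weakening of growth inhibition is expected, a 2.0-fold higher number from compound 2 to compound 3 (0.31 log units; beyond the scatter). Compound 3 is estimated at 12000 nM in this assay, with a range from 4000 nM to 40000 nM.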

Compound 3, concentration for total growth inhibition: 26900 nM
Estimate against measurement, compound 3: 2.2-fold (0.35 log units) below, and the stated range covers the measured number.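

In this assay, the place on a saturated chain carbon bound to a nitrogen on an aromatic ring proves sensitive to the aryl group: 4-methoxyphenyl in place of 3,4-dichlorophenyl gives a 4.6-fold higher number from compound 2 to compound 3 (0.66 log units; beyond the scatter). Of this pair, the 3,4-dichlorobenzyl compound therefore holds the stronger growth inhibition. Nothing at hand gives a cause for this step.

The compounds shown do not separate the loss of the chlorine atoms from the arrival of the methoxy group. An unsubstituted phenyl or a 4-chlorophenyl at this place would tell the two apart.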